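The source may hold more compounds than are shown below. What is called first, only, known or untested is meant among the compounds shown, and "the series" means these compounds.

Compound 3 `Cc1ccccc1-c1nn(-c2ccc(F)cc2F)cc1CNCCCN1CCN(C)CC1` has been examined in an ADME assay on Huh-7 cells (Homo sapiens) for cytotoxicity; on this read-out lower numbers stand for higher toxicity in this test and higher numbers for lower toxicity in this test. In this assay compound 3 gives > 20000 nM, which is a limit of the assay rather than a number. Its two neighbours stand the same way. Compound 1 `Cc1ccccc1-c1nn(-c2ccc(F)cc2F)cc1CNCCN1CCN(C)CC1` gives > 20000 nM in this assay, again a limit. Compound 2 `CCN(CC)CCCNCc1cn(-c2ccc(F)cc2F)nc1-c1ccccc1C` gives > 20000 nM in this assay, also a limit. All three values therefore share (the limit of > 20000 nM in this assay, at which 3 of the 3 values shown sit), so the steps among them cannot be sized: a step that the two limits leave unreadable from compound 1 to compound 2, a step that the two limits leave unreadable from compound 1 to compound 3 and a step that the two limits leave unreadable from compound 2 to compound 3 are each unreadable, and none of them shows whether the basic tail matters for this read-out.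

Compound 4 `Cc1ccccc1-c1nn(-c2ccc(F)cc2F)cc1CNCCN(C)C` is the next member. Its change from compound 3 is dimethylamino in place of (4-methylpiperazin-1-yl)methyl on a saturated chain carbon, two bonds along the chain from an amine nitrogen, a shortening of the tail that leaves the rest of the shared core untouched. The three unreadable steps give no direction for this change; they only show that three different basic tails all stayed at the limit. On that basis the step that the limit leaves unreadable from compound 3 to compound 4 is expected to be none that can be read, with compound 4 most likely reported at the limit once more. The estimate for compound 4 is accordingly 25000 nM, within a range from 10000 nM to 60000 nM, pending the actual measurement.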

Compound 4, half-maximal cytotoxic concentration: > 20000 nM
Compound 4: only a limit was reported; the forecaster's own chance of this, stated with the estimate: 85%; the middle value is on the limit's open side.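

In this assay compound 4 gives > 20000 nM, which is again a limit of the assay. For the compounds shown here, no step from compound 1, compound 2 or compound 3 to compound 4 can be read, as all four stand at the same limit: the limit of > 20000 nM in this assay, at which 4 of the 4 values shown sit. The compounds shown leave open whether changing the tail has any effect on the read-out in this assay.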